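A few compounds are considered here, and "the series" means these few. Any claim that something is new, unique, unknown or untested is made for them only; others in the source may bear on it.

Measured in an ADME assay (liver) for metabolic stability, with Liver microsome (Homo sapiens) as the target, using microsomes and NADPH, with a stated time of 30 min, tested at 1 uM; a higher number here means faster removal of the compound, a lower number slower removal:
- Compound 1 `CS(=O)(=O)Nc1cccc(-c2cc(C(O)(C(F)(F)F)C(F)(F)F)cnc2N2CCN(S(=O)(=O)c3ccc(N)nc3)CC2)c1`: 40 mL.min-1.g-1
- Compound 2 `Cc1ccc(-c2cc(C(O)(C(F)(F)F)C(F)(F)F)cnc2N2CCN(S(=O)(=O)c3ccc(N)nc3)CC2)cn1`: 43 mL.min-1.g-1
- Compound 3 `COc1cncc(-c2cc(C(O)(C(F)(F)F)C(F)(F)F)cnc2N2CCN(S(=O)(=O)c3ccc(N)nc3)CC2)c1`: 44 mL.min-1.g-1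

These three compounds share a core and differ only in one aromatic group. Compound 3, at 44 mL.min-1.g-1, cannot be separated from the other two on these numbers, as all three lie within the scatter of one another.

The next compound to be considered is compound 4 `Nc1ccc(S(=O)(=O)N2CCN(c3ncc(C(O)(C(F)(F)F)C(F)(F)F)cc3-c3ccc4c(c3)CC(=O)N4)CC2)cn1`. It differs from compound 3 by a group of 10 heavy atoms (8 carbon, 1 nitrogen, 1 oxygen; one five-membered non-aromatic ring with 1 hetero atom, one six-membered aromatic ring of carbon only) in place of a group of 8 heavy atoms (6 carbon, 1 nitrogen, 1 oxygen; one six-membered aromatic ring with 1 hetero atom), on an aromatic carbon. The change sits on an aromatic carbon of a six-membered aromatic ring with 1 nitrogen, the same place that varies across the measured compounds.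

Among the measured compounds shown here, three measured steps bear on it: a 1.1-fold higher number from compound 1 to compound 2 (0.03 log units; within the scatter), a 1.1-fold higher number from compound 1 to compound 3 (0.04 log units; within the scatter) and a 1.0-fold higher number from compound 2 to compound 3 (0.01 log units; within the scatter). All are within the scatter in this assay, so exchanges at this place have so far left the number unmoved. However, none of the measured compounds carries a five-membered non-aromatic ring in this group, so the evidence for compound 4 is indirect.

No shift beyond the scatter is therefore expected, and no direction can be favoured. The expected step is a 1.0-fold lower number from compound 3 to compound 4 (0.02 log units; within the scatter). For compound 4 the estimated value is 42 mL.min-1.g-1, with an expected range from 21 mL.min-1.g-1 to 80 mL.min-1.g-1.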

Compound 4, intrinsic clearance in microsomes: < 14 mL.min-1.g-1
Compound 4: no number, only a limit; the forecaster's own chance of this, stated with the estimate: 3%; at least 3.0-fold (0.47 log units) between middle value and limit.
By their numbers in this assay, from the lowest: compounds 1, 2 and 3 (each within the scatter of the next). At a limit, below all of these: compound 4.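

In this assay compound 4 gives only a limit and not a number: (the limit of < 14 mL.min-1.g-1 in this assay, at which 1 of the 4 values shown sits). Among the compounds shown here, this position had so far left the number unmoved across a 3-(methanesulfonamido)phenyl, a 6-methylpyridin-3-yl and a 5-methoxypyridin-3-yl group, yet it is now seen to respond to the group placed on it, with all three new steps lying beyond the scatter (an at least 3.1-fold lower number from compound 3 to compound 4 (0.49 log units; beyond the scatter)) and (an at least 3.0-fold lower number from compound 2 to compound 4 (0.48 log units; beyond the scatter)) and (an at least 2.8-fold lower number from compound 1 to compound 4 (0.45 log units; beyond the scatter)). Slower removal is therefore possible with the core of compound 1 unchanged, and the one exchange that gives it brings in a five-membered non-aromatic ring with 1 hetero atom on a six-membered aromatic ring of carbon only, a feature absent from the three earlier groups.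

The compounds shown do not tell how far the true value of compound 4 lies beyond its limit, so the full size of these steps stays unknown. Nor do they tell which part of the entering group matters, since a plain phenyl group, or a phenyl carrying an open acetamido chain, does not appear among them to separate the ring and its carbonyl from the carbon-only aromatic ring.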